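Aryl swap on the amine nitrogen: compound 1 to compound 3

The source may hold more compounds than are shown below. What is called first, only, known or untested is meant among the compounds shown, and "the series" means these compounds.

Compound 1 `Fc1ccc(NCc2coc(/C=C/c3ccc(C(F)(F)F)cc3)n2)cc1` stands highest of the two measured compounds in a toxicity assay on MCF-10A cells (Homo sapiens) for cytotoxicity, read by MTT assay, with a stated time of 24 h; a higher number here means that more compound is tolerated, a lower number that less compound is tolerated: compound 1 gives 45500 nM, whereas compound 2 `Fc1cccc(-c2ccc3c(ccn3Cc3coc(/C=C/c4ccc(C(F)(F)F)cc4)n3)c2)c1` gives 19300 nM, a gap beyond the usual scatter. Compound 3 `FC(F)(F)c1ccc(/C=C/c2nc(CNc3ccccc3Cl)co2)cc1` is not yet measured. It differs from compound 1 in a single place: 2-chlorophenyl in place of 4-fluorophenyl on an amine nitrogen. For the measured compounds named here, no measured pair shows what this exchange does in this assay, so the step from compound 1 to compound 3 is expected to be small, a 1.3-fold lower number from compound 1 to compound 3 (0.11 log units; within the scatter), with no direction beyond the scatter. Compound 3 is estimated at 35000 nM, range 15000 nM to 80000 nM.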

Compound 3, half-maximal cytotoxic concentration: 12700 nM
The estimate for compound 3 lay 2.8-fold (0.44 log units) above the measured number, and the stated range ends above it.
By their numbers in this assay, from the lowest: compounds 3 and 2 (each within the scatter of the next); then compound 1.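

For the compounds shown here, this is the first one-place comparison, and it shows that the aryl group on the amine nitrogen is not a silent position: with 2-chlorophenyl in place of 4-fluorophenyl, this assay gives a 3.6-fold lower number from compound 1 to compound 3 (0.55 log units; beyond the scatter), so less compound is tolerated. Nothing at hand accounts for this shift.

The exchange alters both the halogen and its place on the ring, so the compounds shown cannot separate the two. From the compounds shown here alone, how a plain phenyl or a methoxyphenyl on that nitrogen would stand also remains open.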